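Amide aryl swap in the shared-core series

The source may hold more compounds than are shown below. What is called first, only, known or untested is meant among the compounds shown, and "the series" means these compounds.

Measured compounds:
compound 1 `Cc1cccc(NC(=O)CN2CCC(c3ccccc3C#N)CC2)c1` with 71%
compound 2 `Cc1cc(NC(=O)CN2CCC(c3cccc[n+]3[O-])CC2)ccc1F` with 75%

Both compounds were run in a functional assay on HEK293 cells for agonist activity at D(4) dopamine receptor (Homo sapiens), read by FLIPR; a higher number here means a larger maximal response, a lower number a smaller maximal response. Compound 1 gives 71% and compound 2 gives 75%; the two numbers fall within the usual scatter of each other, so nothing separates them. For the measured compounds named here, no step between measured compounds that differ in one place is available, and compound 1 and compound 2 differ in more than one place.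

Compound 3 `Cc1ccc(Cl)cc1NC(=O)CN1CCC(c2cccc[n+]2[O-])CC1` keeps the core of compound 2 and differs only in the group on the amide-type nitrogen:
5-chloro-2-methylphenyl in place of 4-fluoro-3-methylphenyl on an amide-type nitrogen

Going by the values given here, nothing among the measured compounds separates variations of this aryl group by more than the scatter. In this assay the step from compound 2 to compound 3 is expected to be small a number 5 percentage points lower from compound 2 to compound 3 (within the scatter) and not beyond the scatter, if anything slightly downward. Compound 3 is therefore estimated at 70%, with a range from 50% to 90%.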

Compound 3, largest response reached (reported as efficacy), in percent of the reference or control that the assay uses: 58%
For compound 3 the middle estimate is 12 percentage points above the measured one; low and high end bracket the measured number.
By their numbers in this assay, from the lowest: compound 3; then compounds 1 and 2 (each within the scatter of the next).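

In this assay, for the compounds shown here, 5-chloro-2-methylphenyl in place of 4-fluoro-3-methylphenyl on the amide-type nitrogen gives a number 17 percentage points lower from compound 2 to compound 3 (beyond the scatter), the only step that can be read so far, and it shows that maximal response at this position depends on the aryl group. Both groups are methyl- and halogen-bearing phenyl rings, yet this change moves the response beyond the scatter. No available evidence accounts for the drop.

Since fluorine becomes chlorine and the substituent pattern changes in the same step, the two contributions remain unseparated. Also open, from the compounds shown here alone, are how an unsubstituted phenyl or a methoxyphenyl on the amide-type nitrogen would read, and whether the same change would give a similar step on the core of compound 1.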